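Cyclic versus acyclic amines on the naphthalenesulfonamide series

A few compounds are considered here, and "the series" means these few. Any claim that something is new, unique, unknown or untested is made for them only; others in the source may bear on it.

Compound 1 `CCC1CCC(C)N(C[C@@H](O)CNS(=O)(=O)c2cccc3ccccc23)C1`, compound 2 `CCCN(C[C@@H](O)CNS(=O)(=O)c1cccc2ccccc12)C(C)CC` and compound 3 `O=S(=O)(NC[C@H](O)CN1CCCC1C1CC1)c1cccc2ccccc12` share the naphthalenesulfonamide core with a hydroxypropyl linker to a basic amine. In an assay on HEK293 cells for inhibition of sodium- and chloride-dependent glycine transporter 1 (Homo sapiens) (a lower number here means a stronger inhibitor, a higher number a weaker inhibitor), compound 1 gives 1000 nM and compound 2 gives 1260 nM; the step of a 1.3-fold higher number from compound 1 to compound 2 (0.10 log units; within the scatter) is within the scatter. Compound 3 has two entries in this assay, 501 nM; 1580 nM (2 entries), which themselves show how far repeats of one compound can lie apart (the several entries of compound 3 in this assay, 501 nM; 1580 nM (2 entries)). On the numbers given, compound 2 holds the highest of the two single values, with compound 1 as its nearest neighbour.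

Compound 4 `O=S(=O)(NC[C@H](O)CN1CCCCC1)c1cccc2ccccc12` is not yet measured. The change from compound 2 is piperidin-1-yl in place of propyl(sec-butyl)amino on a saturated chain carbon, two bonds along the chain from an oxygen on a saturated carbon. Among the measured compounds shown here, the only measured step that bears on it is the opposite exchange, a ring-opened amine for a ring-closed one, a 1.3-fold higher number from compound 1 to compound 2 (0.10 log units; within the scatter), which stayed within the scatter. Compound 3 carries a ring amine as well, and its two entries bracket the values of compound 1 and compound 2. No step beyond the scatter is therefore expected in this assay for compound 4; the expected step is a 1.4-fold lower number from compound 2 to compound 4 (0.15 log units; within the scatter). Compound 4 is estimated at 900 nM, with a range from 400 nM to 2200 nM.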

Compound 4, half-maximal inhibitory concentration: 3160 nM
For compound 4 the middle estimate is 3.5-fold (0.55 log units) below the measured one, and the stated range ends below it.
By their numbers in this assay, from the lowest: compounds 1 and 2 (each within the scatter of the next); then compound 4.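

In this assay, the amine on the saturated chain carbon, two bonds along the chain from an oxygen on a saturated carbon, now makes a readable difference: the exchange for piperidin-1-yl gives a 2.5-fold higher number from compound 2 to compound 4 (0.40 log units; beyond the scatter) and a 3.2-fold higher number from compound 1 to compound 4 (0.50 log units; beyond the scatter), both modest. A ring alone therefore does not preserve the number seen with 5-ethyl-2-methylpiperidin-1-yl, as the unsubstituted ring of compound 4 lies beyond the scatter of that compound, and the earlier equivalence of a ring-closed and an open-chain amine holds only for the pair of substituted amines. These steps remain modest, and repeats of a single compound in this series can lie well apart: the several entries of compound 3 in this assay, 501 nM; 1580 nM (2 entries)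

The compounds shown do not separate the contributions of the ethyl and methyl groups, so it remains open whether 2-methylpiperidin-1-yl or 3-ethylpiperidin-1-yl alone would restore the number of compound 1. Also open, as far as these compounds go, is how a ring with a further hetero atom, such as morpholin-4-yl, or a smaller unsubstituted ring, such as pyrrolidin-1-yl, would read at this position.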